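A few compounds are considered here, and "the series" means these few. Any claim that something is new, unique, unknown or untested is made for them only; others in the source may bear on it.

Of the compounds shown here, three of a shared core have been measured in a functional assay on MGC-803 cells (Homo sapiens) for inhibition, read by MTT assay, with a stated time of 48 h; on this read-out lower numbers stand for stronger inhibition and higher numbers for weaker inhibition. Compound 1, `Cc1ccc(NC(=S)NC(=O)c2ccc(OCc3ccccc3Cl)cc2)cc1-c1nc2ccccc2[nH]1`, gives 45000 nM. Compound 2, `Cc1ccc(NC(=O)NC(=O)c2ccc(OCc3cccc(C(F)(F)F)c3)cc2)cc1-c1nc2ccccc2[nH]1`, gives 13100 nM. Compound 3, `Cc1ccc(NC(=O)NC(=O)c2ccc(OCc3ccccc3F)cc2)cc1-c1nc2ccccc2[nH]1`, gives 2520 nM, the lowest of the three numbers; its nearest neighbour is compound 2 and the furthest is compound 1. Among the compounds with values here, the one single-point step among them is a 5.2-fold lower number from compound 2 to compound 3 (0.72 log units; beyond the scatter), a change of the group on the saturated chain carbon bound to the oxygen on the aromatic ring. Compound 4, `Cc1ccc(NC(=O)NC(=O)c2ccc(OCc3cccc(F)c3)cc2)cc1-c1nc2ccccc2[nH]1`, has not yet been measured in this assay. It differs from compound 3 by 3-fluorophenyl in place of 2-fluorophenyl on a saturated chain carbon bound to an oxygen on an aromatic ring. The measured step bears on this only loosely, since it swapped a different group at the same place, so the size of the coming step is uncertain. Compound 4 is therefore expected to sit near compound 3, with a step of a 1.6-fold higher number from compound 3 to compound 4 (0.20 log units; within the scatter). For compound 4 the estimate in this assay is 4000 nM, within a range from 1500 nM to 12000 nM.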

Compound 4, half-maximal inhibitory concentration: 44800 nM
Compound 4: the middle estimate sits 11-fold (1.05 log units) below what was measured, and the stated range ends below it.
By their numbers in this assay, from the lowest: compound 3; then compound 2; then compounds 4 and 1 (each within the scatter of the next).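

In this assay, the move from 2-fluorobenzyl to 3-fluorobenzyl gives an 18-fold higher number from compound 3 to compound 4 (1.25 log units; beyond the scatter), so at this place the outcome depends on where the fluoro stands and not merely on its presence. Fluoro in place of trifluoromethyl on an aromatic carbon gives a 3.4-fold higher number from compound 2 to compound 4 (0.53 log units; beyond the scatter), a smaller step, which shows that the low number of compound 3 goes with 2-fluorophenyl and not with fluoro as such. No measurement at hand explains the gap between these two isomers.

The compounds shown leave open whether 2-methoxyphenyl or another group at this place would keep the low number of compound 3. They also leave open what the sulfur of compound 1 contributes, since that compound differs from compound 3 in more than one place.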